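This account rests on a few compounds, and the source may have more. Where it says the series, first, only, none or still open, it means among the compounds named here.

Measured so far:
Compound 1 `NC(=O)Cn1c(=O)n(C2OC(CO)[C@@H](O)[C@H]2O)c2nc(N)nc(O)c21` — 32%
Compound 2 `C=CCn1c(=S)n(COCCO)c2nc(N)nc(O)c21` — 9%

Both compounds were tested in a functional assay on the whole organism (B cells) with Mus musculus as the target; on this read-out lower numbers stand for smaller maximal responses and higher numbers for larger maximal responses. Compound 1 reaches 32%, the higher of the two numbers, while compound 2 reaches 9%, a gap beyond the usual scatter. The two structures differ in more than one place, so the gap cannot be tied to a single change; the values simply show that compound 1 stands higher.

Compound 3 `Nc1nc(O)c2c(n1)n(C1OC(CO)[C@@H](O)[C@H]1O)c(=O)n2CCN1CCCCC1` is not yet measured. It differs from compound 1 in one place: (piperidin-1-yl)methyl in place of carbamoyl on a saturated chain carbon bound to an aromatic nitrogen. Within the data shown here, no pair of measured compounds shows what this kind of change does, so the expectation rests on compound 1 alone. The step of a number 6 percentage points lower from compound 1 to compound 3 (within the scatter) is expected to be small, most likely within the scatter, with a slight lean downward. For compound 3, a maximal response of about 26% is estimated, with a range from 8% to 45%.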

Compound 3, largest response reached (reported as maximal response), in percent of the reference or control that the assay uses: 0%
Compound 3: the middle estimate sits 26 percentage points above what was measured; measured number outside the range, below it.
By their numbers in this assay, from the lowest: compounds 3 and 2 (each within the scatter of the next); then compound 1.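

In this assay, among these compounds, carbamoyl giving way to (piperidin-1-yl)methyl on a saturated chain carbon bound to an aromatic nitrogen comes with a number 32 percentage points lower from compound 1 to compound 3 (beyond the scatter), the first step in this set that can be tied to a single change. It shows that the maximal response depends strongly on the group at this place: with the rest of the structure unchanged, compound 3 gives 0% in this assay. No measurement shown here accounts for this step.

It remains open whether the drop follows from the arrival of the (piperidin-1-yl)methyl group or from the departure of carbamoyl, as only one replacement at this place is shown. A carboxylic acid or an open-chain dimethylamino group on the same chain would help tell these two readings apart.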